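Working notes: the step from compound 3 to compound 4

The compounds below may be only part of what the source reports. "The series", "measured", "known", "first", "only" and "open" are said of these compounds alone.

Measured so far:
compound 1, `Nc1ccccc1Nc1n[n+]([O-])c2ccccc2[n+]1[O-]`: 16100 nM
compound 2, `COc1ccc(Nc2n[n+]([O-])c3ccccc3[n+]2[O-])cc1`: 12000 nM
compound 3, `C=CCNc1n[n+]([O-])c2ccccc2[n+]1[O-]`: > 56000 nM (a limit, not a number)

Three compounds sharing one core have been run in a functional assay on PC-3 cells (Homo sapiens) for cytotoxicity, read by MTT assay, with a stated time of 48 h; a lower number here means a stronger inhibitor, a higher number a weaker inhibitor. Compound 1 gives 16100 nM and compound 2 gives 12000 nM, and the two sit within the usual scatter of each other. For compound 3 this assay reports only a limit, > 56000 nM, and no number. That is where compound 3 stands: at the limit of > 56000 nM in this assay, at which 1 of the 3 values shown sits, with no number of its own, the weakest position shown among the three.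

Compound 4, `CCNc1n[n+]([O-])c2ccccc2[n+]1[O-]`, has not yet been measured in this assay. It differs from compound 3 in one place: methyl in place of vinyl on a saturated chain carbon bound to a nitrogen on an aromatic ring. Going by the values given here, no step between measured compounds isolates this change, so no measured step can be pointed to for guidance. The change is small, allyl to ethyl, with a vinyl leaving and a methyl entering on a saturated chain carbon bound to a nitrogen on an aromatic ring. The expectation is that compound 4 stays where compound 3 stands, the step from compound 3 to compound 4 estimated as a step that the limit leaves unreadable from compound 3 to compound 4, nothing beyond the scatter in either direction. Compound 4 is therefore expected at about 70000 nM, within 25000 nM to 200000 nM, and this assay will most likely again report only a limit for compound 4.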

Compound 4, half-maximal inhibitory concentration: 13300 nM
Estimate against measurement, compound 4: 5.3-fold (0.72 log units) above, and the stated range ends above it.
By their numbers in this assay, from the lowest: compounds 2, 4 and 1 (each within the scatter of the next). At a limit, above all of these: compound 3.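

In this assay, this position responds to a small change in the chain: allyl to ethyl gives an at least 4.2-fold lower number from compound 3 to compound 4 (0.62 log units; beyond the scatter). Compound 3 alone could suggest that any short open chain on this nitrogen leaves the series at a limit, but the ethylamino group of compound 4 rules that reading out, so the allylamino result does not extend to short chains in general. The size of the step stays unknown and only its minimum can be read, because compound 3 stands at a limit and has no number of its own: the limit of > 56000 nM in this assay, at which 1 of the 4 values shown sits.

The compounds shown leave open whether the vinyl double bond or the additional chain carbon accounts for the difference, and a propyl chain in place of allyl would separate the two. Also open, from the compounds shown here alone, is how the read-out in this assay responds to other groups at this position, such as a methyl group, a cyclopropyl group or a hydroxyethyl chain, each of which would show how far the ethyl result extends.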